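The source may hold more compounds than are shown below. What is called first, only, known or untested is meant among the compounds shown, and "the series" means these compounds.

Measured so far:
- compound 1, `COc1ccc(S(=O)(=O)N2CCc3cccc(-c4ccc(C#N)cc4)c32)cc1`: 24.2 nM
- compound 2, `COc1ccc(S(=O)(=O)N2CCc3cccc(-c4ccc(N)cc4)c32)cc1`: 301 nM

Compound 1 has the lowest of the two numbers in a functional assay on HT-29 cells (Homo sapiens) for inhibition, with a stated time of 72 h (a higher number here means a weaker inhibitor, a lower number a stronger inhibitor), and its nearest neighbour is compound 2. Among the measured compounds shown here, the only measured step is a 12-fold higher number from compound 1 to compound 2 (1.09 log units; beyond the scatter), which shows that changing the group on the para position of the pendant phenyl ring has a large effect.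

The unmeasured compound 3, `COc1ccc(S(=O)(=O)N2CCc3cccc(-c4cccc(F)c4)c32)cc1`, differs from compound 1 by 3-fluorophenyl in place of 4-cyanophenyl on an aromatic carbon. Here the group moves to a different position and the only hydrogen-bond acceptor of the pendant ring is lost. The step to compound 2, which also removed the cyano, bears on this, although the entering group differs in kind and position. A loss of potency of moderate to large size is therefore expected, though the direction cannot be fixed with certainty from one step.

For compound 3 the expected value in this assay is 120 nM, with a range from 30 nM to 500 nM, corresponding to an estimated step of a 5.0-fold higher number from compound 1 to compound 3 (0.70 log units; beyond the scatter).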

Compound 3, half-maximal inhibitory concentration: 119 nM
The estimate for compound 3 lay 1.0-fold (0.00 log units) above the measured number, within the range that was stated.
By their numbers in this assay, from the lowest: compound 1; then compound 3; then compound 2.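

In this assay, a pendant ring without the nitrile can still give a fairly strong inhibitor: there is a 4.9-fold higher number from compound 1 to compound 3 (0.69 log units; beyond the scatter) and, on the other side, a 2.5-fold lower number from compound 2 to compound 3 (0.40 log units; beyond the scatter) in this series. Losing 4-cyanophenyl at this aromatic carbon therefore costs potency, but the size of the cost depends on what enters, and 3-fluorophenyl is better tolerated here than 4-aminophenyl. No supporting data are available to explain this order.

The change from compound 1 to compound 3 swaps both the substituent and its place on the ring, so the contribution of each remains unseparated. As far as these compounds go, a plain phenyl ring, or a nitrile or a fluorine moved to the other ring position, would help to tell them apart, and a carboxylic acid or a methoxy group remains unexplored.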